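The source may hold more compounds than are shown below. What is called first, only, known or untested is meant among the compounds shown, and "the series" means these compounds.

Measured so far in a functional assay on MCF7 cells (Homo sapiens) for antiproliferative activity, read by MTT assay, with a stated time of 48 h; a higher number here means a weaker inhibitor, a lower number a stronger inhibitor:
Compound 1 `CC(=O)N1N=C(c2ccc3ccccc3c2)OC1c1ccccc1Cl`: 2.36 ug/mL
Compound 2 `CC(=O)N1N=C(c2ccc3ccccc3c2)OC1c1ccccc1F`: 3.44 ug/mL

Within the data shown here, compound 2 has only one measured neighbour, and the two values lie within the scatter of each other. Among the measured compounds shown here, the single step known so far is a 1.5-fold higher number from compound 1 to compound 2 (0.16 log units; within the scatter).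

Compound 3 `CC(=O)N1N=C(c2ccc3ccccc3c2)OC1c1ccc(F)cc1` keeps the shared core and differs from compound 2 at one place: 4-fluorophenyl in place of 2-fluorophenyl on a saturated ring carbon. In words, it carries 4-fluorophenyl in place of 2-fluorophenyl on a saturated ring carbon. For the measured compounds named here, no measured step covers this kind of change. The closest evidence is the halogen exchange on the same aromatic ring, a 1.5-fold higher number from compound 1 to compound 2 (0.16 log units; within the scatter), so no step beyond the scatter is expected in this assay, and the data indicate no direction. The expected step is a 1.1-fold lower number from compound 2 to compound 3 (0.06 log units; within the scatter). Compound 3 is estimated at 3 ug/mL, with an expected range of 1.3 ug/mL to 7 ug/mL.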

Compound 3, half-maximal inhibitory concentration: 3.02 ug/mL
Estimate against measurement, compound 3: 1.0-fold (0.00 log units) below, and the stated range covers the measured number.
By their numbers in this assay, from the lowest: compounds 1, 3 and 2 (each within the scatter of the next).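

In this assay, the place of the fluorine on the phenyl group at the saturated ring carbon can now be read: 4-fluorophenyl in place of 2-fluorophenyl gives a 1.1-fold lower number from compound 2 to compound 3 (0.06 log units; within the scatter). Set against the 2-chlorophenyl group, 4-fluorophenyl gives a 1.3-fold higher number from compound 1 to compound 3 (0.11 log units; within the scatter), which puts all three groups shown at this carbon within the scatter of one another, and neither the halogen nor its place on the phenyl group separates these compounds in this assay. Nothing available bears on why these values lie so close together.

All three compounds carry a single halogen on this phenyl group, which leaves open how a methoxy group, an amine or a carboxylic acid there would read. From the compounds shown here alone, what a longer chain in place of the acetyl group would do also remains open.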